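The compounds below may be only part of what the source reports. "The series", "measured", "known", "first", "only" and "open" are said of these compounds alone.

Values in a functional assay on OVCAR-3 cells (Homo sapiens) for inhibition, read by MTT assay, with a stated time of 24 h (a higher number here means a weaker inhibitor, a lower number a stronger inhibitor), for the measured members of the series:

compound 1 `CC1(C)[C@H]2CC[C@]1(C)N(Cc1cn(-c3cccc(Cl)c3)nn1)C(=O)C2`: 50 nM
compound 2 `CC1(C)[C@H]2CC[C@]1(C)N(Cc1cn(-c3ccccc3O)nn1)C(=O)C2`: 90 nM
compound 3 `CC1(C)[C@H]2CC[C@]1(C)N(Cc1cn(-c3ccccc3)nn1)C(=O)C2`: 50 nM

Compound 1 stands level with compound 3 at the digits recorded, the two together giving the lowest numbers of the three; its furthest neighbour is compound 2, with a 1.8-fold higher number from compound 1 to compound 2 (0.26 log units; within the scatter). The whole spread of the set therefore lies within the scatter of the assay.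

The next compound, compound 4 `CC1(C)[C@H]2CC[C@]1(C)N(Cc1cn(-c3ccccc3C#N)nn1)C(=O)C2`, differs from compound 1 only on the aromatic nitrogen of the triazole portion of the shared core: 2-cyanophenyl in place of 3-chlorophenyl on an aromatic nitrogen.

Within the data shown here, three measured steps bear on this change, all at the same place. Removing the chloro gave no change at the digits printed from compound 1 to compound 3 (within the scatter). Exchanging the aryl group for 2-hydroxyphenyl gave a 1.8-fold higher number from compound 1 to compound 2 (0.26 log units; within the scatter), and removing that hydroxy gave a 1.8-fold lower number from compound 2 to compound 3 (0.26 log units; within the scatter). None of these steps left the scatter, so the position tolerates a bare phenyl, a chloro and a hydroxy substituent alike. Among the measured compounds shown here, a cyano group at the same ring has no precedent in the set, but nothing recorded points to a step beyond the scatter in this assay in either direction.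

Compound 4 is therefore estimated at 60 nM, with a range from 25 nM to 150 nM. That estimate corresponds to an expected 1.2-fold higher number from compound 1 to compound 4 (0.08 log units; within the scatter).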

Compound 4, half-maximal inhibitory concentration: 110 nM
Compound 4: the middle estimate sits 1.8-fold (0.26 log units) below what was measured, within the range that was stated.
By their numbers in this assay, from the lowest: compounds 1, 3, 2 and 4 (each within the scatter of the next, the first and the last beyond it).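

In this assay, among these compounds, the 2-cyanophenyl group gives the first steps at this position that leave the scatter: a 2.2-fold higher number from compound 1 to compound 4 (0.34 log units; beyond the scatter) for the exchange of the whole aryl group, and a 2.2-fold higher number from compound 3 to compound 4 (0.34 log units; beyond the scatter) for cyano added in place of hydrogen on the bare phenyl, both modest. The position is therefore not indifferent to every substituent on this ring, although the limit shows only weakly: the comparison with the hydroxy compound gives a 1.2-fold higher number from compound 2 to compound 4 (0.09 log units; within the scatter), so cyano and hydroxy are not separated here, and compound 4 alone stands apart from compound 1 and compound 3, while compound 2 stands apart from none of the others. Nothing on hand speaks to the origin of this step.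

Whether the step belongs to the cyano group itself or to where it sits on the ring stays open: the compounds shown carry cyano at a single place. Going by these compounds, how an amine, a carboxylic acid or a methoxy group on the same ring would read in this assay is also open, as is whether any of them would go further than cyano.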